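Carbon substituents on the ring amine nitrogen: outlook for compound 4

A few compounds are considered here, and "the series" means these few. Any claim that something is new, unique, unknown or untested is made for them only; others in the source may bear on it.

Measured in a functional assay on HeLa cells (Homo sapiens) for cytotoxicity, read by MTT assay, with a stated time of 48 h; on this read-out higher numbers stand for weaker inhibition and lower numbers for stronger inhibition:
compound 1 `CCN(CC)c1ccc2cc(C(=O)c3ccc(N4CCN(C(=O)CN5CCN(C(=O)CCl)CC5)CC4)cc3)oc2c1` gives 5520 nM.
compound 2 `CCN(CC)c1ccc2cc(C(=O)c3ccc(N4CCN(C(=O)CN5CCN(S(=O)(=O)c6ccc(C#N)cc6)CC5)CC4)cc3)oc2c1` gives 8470 nM.
compound 3 `C#CCN1CCN(CC(=O)N2CCN(c3ccc(C(=O)c4cc5ccc(N(CC)CC)cc5o4)cc3)CC2)CC1` reaches only the assay limit, > 40000 nM.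

Compound 1 holds the lowest of the two numbers; its nearest neighbour is compound 2, with a 1.5-fold higher number from compound 1 to compound 2 (0.19 log units; within the scatter). Compound 3 sits at the limit (the limit of > 40000 nM in this assay, at which 1 of the 3 values shown sits).

Compound 4 `CCN(CC)c1ccc2cc(C(=O)c3ccc(N4CCN(C(=O)CN5CCN(Cc6ccc(C(F)(F)F)cc6)CC5)CC4)cc3)oc2c1` differs from compound 1 in one place: 4-(trifluoromethyl)benzyl in place of (chloromethyl)carbonyl on an amine nitrogen in a ring.

Among the compounds with values here, two measured steps bear on this change, both putting a carbon substituent on the same ring amine nitrogen in place of a carbonyl or sulfonyl group: an at least 7.2-fold higher number from compound 1 to compound 3 (0.86 log units; beyond the scatter) and an at least 4.7-fold higher number from compound 2 to compound 3 (0.67 log units; beyond the scatter). A carbon substituent there therefore goes with a clearly higher number, beyond the scatter. The 4-(trifluoromethyl)benzyl group is larger than propargyl and carries an aromatic ring, so the size of the shift is less certain than its direction.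

Compound 4 is expected to give about 20000 nM, with a range of 7000 nM to 60000 nM. This estimate means a 3.6-fold higher number from compound 1 to compound 4 (0.56 log units; beyond the scatter), a step beyond the scatter toward a higher number.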

Compound 4, half-maximal inhibitory concentration: > 40000 nM
Compound 4: only a limit was reported; the forecaster's own chance of this, stated with the estimate: 35%; at least 2.0-fold (0.30 log units) between middle value and limit.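

In this assay compound 4 gives only a limit, > 40000 nM. With 4-(trifluoromethyl)benzyl on the amine nitrogen in a ring, the series shows an at least 7.2-fold higher number from compound 1 to compound 4 (0.86 log units; beyond the scatter) and an at least 4.7-fold higher number from compound 2 to compound 4 (0.67 log units; beyond the scatter), so a second carbon substituent, this one carrying an aromatic ring, goes with a higher number, as propargyl does in compound 3. The step between compound 3 and compound 4 cannot be read, and both now sit at the same limit: the limit of > 40000 nM in this assay, at which 2 of the 4 values shown sit.

Open, from the compounds shown here alone, is whether the lower numbers of compound 1 and compound 2 follow the carbonyl or sulfonyl link on this nitrogen as such, or the particular groups carried there. An acetyl or benzoyl group on this nitrogen would separate those two readings, and a plain benzyl group would test the carbon side.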